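Azido replacing the silicon-bearing group: working notes

This account rests on a few compounds, and the source may have more. Where it says the series, first, only, none or still open, it means among the compounds named here.

compound 1 `CC(C)=CCC[C@]1(C)/C=C/[C@@H](OC(=O)C=C(C)C)[C@](C)(O)/C=C/C(=O)/C(CF)=C\C1`: 240 nM
compound 2 `CCN(CC)C/C1=C/C[C@](C)(CCC=C(C)C)/C=C/[C@@H](OC(=O)C=C(C)C)[C@](C)(O)/C=C/C1=O`: 130 nM
compound 3 `CC(C)=CCC[C@]1(C)/C=C/[C@@H](OC(=O)C=C(C)C)[C@](C)(O)/C=C/C(=O)/C(C[Si](C)(C)C(C)(C)C)=C\C1`: 6040 nM

All three values come from a functional assay on MCF7 cells (Homo sapiens) for antiproliferative activity, read by MTT assay, with a stated time of 48 h; on this read-out higher numbers stand for weaker inhibition and lower numbers for stronger inhibition. In this assay compound 3 gives the highest number of the set, 6040 nM, and so the weakest inhibition. Compound 4 `CC(C)=CCC[C@]1(C)/C=C/[C@@H](OC(=O)C=C(C)C)[C@](C)(O)/C=C/C(=O)/C(CN=[N+]=[N-])=C\C1` keeps the shared core and changes one group: a group of 3 heavy atoms (3 nitrogen; no ring) in place of a group of 7 heavy atoms (6 carbon, 1 silicon; no ring), on a saturated chain carbon bound to a double-bonded ring carbon. The entering group is azido.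

Going by the values given here, three measured steps bear on this change, all at the same place. The step of a 1.8-fold lower number from compound 1 to compound 2 (0.27 log units; within the scatter) lies within the scatter, so fluoro and diethylamino give values that cannot be told apart. The steps of a 25-fold higher number from compound 1 to compound 3 (1.40 log units; beyond the scatter) and a 46-fold higher number from compound 2 to compound 3 (1.67 log units; beyond the scatter) are both large and beyond the scatter. Among these three compounds, only compound 3 stands apart, and no compound goes against that reading. Among the compounds with values here, the set holds no azido compound, so the expectation rests on just these comparisons. Compound 4 loses the group found only in compound 3, and it is therefore expected to fall near compound 1 at 240 nM rather than near compound 3.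

A large fall in the number is expected, a 20-fold lower number from compound 3 to compound 4 (1.30 log units; beyond the scatter). The estimated value for compound 4 is 300 nM, with an expected range of 100 nM to 1000 nM.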

Compound 4, half-maximal inhibitory concentration: 4890 nM
The estimate for compound 4 lay 16-fold (1.21 log units) below the measured number; the whole stated range lies below it.
By their numbers in this assay, from the lowest: compounds 2 and 1 (each within the scatter of the next); then compounds 4 and 3 (each within the scatter of the next).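

In this assay, azido on a saturated chain carbon bound to a double-bonded ring carbon cannot be told apart from the silicon-bearing group it replaces (a 1.2-fold lower number from compound 3 to compound 4 (0.09 log units; within the scatter)), so compound 3 no longer stands alone at the high end of the set. Azido instead separates clearly from both groups that gave the low numbers, with large steps from fluoro (a 20-fold higher number from compound 1 to compound 4 (1.31 log units; beyond the scatter)) and from diethylamino (a 38-fold higher number from compound 2 to compound 4 (1.58 log units; beyond the scatter)), so this position divides the four compounds into two pairs: compounds 1 and 2, and compounds 3 and 4. Heavy-atom count alone does not sort these pairs, since azido, with 3 heavy atoms, falls with the group of 7 heavy atoms, while diethylamino, the group of 5 heavy atoms, falls with fluoro.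

The compounds shown leave open whether a primary amine, a hydroxyl group, a carboxylic acid or a longer chain at this place would fall with compounds 1 and 2 or with compounds 3 and 4. Nothing available on these compounds explains the division into two pairs.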